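The source may hold more compounds than are shown below. What is called first, only, known or untested is meant among the compounds shown, and "the series" means these compounds.

Measured so far in an assay on isolated protein for inhibition of ubiquitin carboxyl-terminal hydrolase 7 (Homo sapiens), with stated times of 30 min and 2 h; on this read-out higher numbers stand for weaker inhibition and lower numbers for stronger inhibition:
compound 1 `Cn1nc2c(=O)n(CC3(O)CCN(Cc4ccc(-n5ccnc5)cc4Cl)CC3)cnc2c1-c1ccc(CN)cc1` — compound 1 gives 228 nM
compound 2 `Cn1nc2c(=O)n(CC3(O)CCN(Cc4ccc(-c5ccco5)cc4Cl)CC3)cnc2c1-c1ccc(C(N)=O)cc1` — compound 2 gives 80.8 nM
compound 3 `Cn1nc2c(=O)n(CC3(O)CCN(Cc4ccc(-c5ccco5)cc4Cl)CC3)cnc2c1-c1ccc(CO)cc1` — compound 3 gives 42.5 nM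

Compound 1 has the highest number of the three; both other compounds sit beyond the scatter below it, though each differs from compound 1 at more than one place. Compound 4 `Cn1nc2c(=O)n(CC3(O)CCN(Cc4ccc(-c5cncs5)cc4Cl)CC3)cnc2c1-c1ccc(CN)cc1` differs from compound 1 by 1,3-thiazol-5-yl in place of 1H-imidazol-1-yl on an aromatic carbon. Going by the values given here, the only single-point step measured, a 1.9-fold lower number from compound 2 to compound 3 (0.28 log units; within the scatter), lies within the scatter and concerns another position, so it does not bear on this exchange, and no measured pair isolates the change at this place. Compound 4 is therefore expected to stay close to compound 1, with the step of a 1.3-fold lower number from compound 1 to compound 4 (0.13 log units; within the scatter) expected to lie inside the scatter. The estimate for compound 4 is 170 nM, with a range from 55 nM to 520 nM.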

Compound 4, half-maximal inhibitory concentration: 117 nM
Beside the measured number, compound 4's estimate is 1.5-fold (0.16 log units) above it; low and high end bracket the measured number.
By their numbers in this assay, from the lowest: compounds 3, 2, 4 and 1 (each within the scatter of the next, the first and the last beyond it).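

In this assay, going by these compounds alone, the first single-place comparison at this position, putting 1,3-thiazol-5-yl in place of 1H-imidazol-1-yl gives a 1.9-fold lower number from compound 1 to compound 4 (0.29 log units; within the scatter), so these two five-membered aromatic rings cannot be told apart here. Nothing measured on these compounds speaks to why the exchange leaves the read-out within the scatter.

Within the data shown here, this covers only one pair of five-membered rings on one otherwise unchanged molecule. Going by these compounds, whether a six-membered ring such as phenyl or pyridinyl, or a small group such as methoxy, would be accommodated at this position remains open.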